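The source may hold more compounds than are shown below. What is called first, only, known or untested is meant among the compounds shown, and "the series" means these compounds.

Working notes on the series. Compound 3 `Cc1ccc2nc(Cl)c(/C=N/n3cc(-c4ccccc4)nc3N)cc2c1` gives 41500 nM in an ADME assay on HUVEC cells (Homo sapiens) for cytotoxicity, read by MTT assay, with a stated time of 48 h (a higher number here means a weaker inhibitor, a lower number a stronger inhibitor), the second highest of the three numbers recorded so far. Compound 1 `Nc1nc(-c2ccccc2)cn1/N=C/c1cc2ccccc2nc1Cl` gives 46700 nM, and the two sit within the scatter of each other: a 1.1-fold lower number from compound 1 to compound 3 (0.05 log units; within the scatter). Compound 2 `COc1ccc(-c2cn(/N=C/c3cc4ccccc4nc3Cl)c(N)n2)cc1` gives 12400 nM and stands furthest off, reached by a 3.8-fold lower number from compound 1 to compound 2 (0.58 log units; beyond the scatter).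

Compound 4 `Cc1ccc2nc(Cl)c(/C=N/n3cc(-c4ccc(Br)cc4)nc3N)cc2c1` differs from compound 3 by bromo in place of hydrogen on an aromatic carbon. The step that bears on it most is a 3.8-fold lower number from compound 1 to compound 2 (0.58 log units; beyond the scatter), where a group also entered the phenyl ring para to the large group and lowered the number beyond the scatter. The step of a 1.1-fold lower number from compound 1 to compound 3 (0.05 log units; within the scatter) touched the other ring and stayed within the scatter, so it says little about this change. Going by the values given here, no bromo group has yet been tried anywhere, so the expectation rests on a single related step and is held loosely: a modest lowering is expected, a 1.9-fold lower number from compound 3 to compound 4 (0.28 log units; within the scatter), with room on both sides. Compound 4 is expected to give 22000 nM in this assay, with a range from 9000 nM to 50000 nM.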

Compound 4, half-maximal inhibitory concentration: 13400 nM
For compound 4 the middle estimate is 1.6-fold (0.22 log units) above the measured one; measured number inside the range.
By their numbers in this assay, from the lowest: compounds 2 and 4 (each within the scatter of the next); then compounds 3 and 1 (each within the scatter of the next).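

With bromo in place of hydrogen on an aromatic carbon para to a large group, a 3.1-fold lower number from compound 3 to compound 4 (0.49 log units; beyond the scatter) in this assay is beyond the scatter, so the change from phenyl to 4-bromophenyl moves the number on the core of compound 3. Going by these compounds alone, until now, a 3.8-fold lower number from compound 1 to compound 2 (0.58 log units; beyond the scatter) was the only step at this position, and it involved methoxy on the core of compound 1. Two different groups on two different cores have now lowered the number beyond the scatter, while the methyl step on the other ring stays within it. No measurement at hand accounts for the step.

On these data alone, whether an amine, a carboxylic acid or a longer chain at this position would also lower the number remains open. So does the size of the bromo step on the core of compound 1.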